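A few compounds are considered here, and "the series" means these few. Any claim that something is new, unique, unknown or untested is made for them only; others in the source may bear on it.

Of the compounds shown here, three sharing one core have been measured in an ADME assay on cells (Macrophage, Mus musculus) for cytotoxicity, read by resazurin assay, with a stated time of 3 days; a higher number here means a weaker inhibitor, a lower number a stronger inhibitor. Compound 1 `O=C(Nc1ccc(C(F)(F)F)cc1)c1cc(Cl)ccc1O` gives 2800 nM. Compound 2 `O=C(Nc1ccc(F)cc1)c1cc(Cl)ccc1O` gives 17000 nM. Compound 3 `O=C(Nc1cccc(C(F)(F)F)c1F)c1cc(Cl)ccc1O` gives 5300 nM. The difference between the core of compound 1 and the core of compound 3 is not broken down here.

Between compound 1 and compound 2 one change is made: fluoro in place of trifluoromethyl on an aromatic carbon. That change produced a 6.1-fold higher number from compound 1 to compound 2 (0.78 log units; beyond the scatter).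

Compound 4 `O=C(Nc1cccc(F)c1F)c1cc(Cl)ccc1O` has not yet been measured. It differs from compound 3 by fluoro in place of trifluoromethyl on an aromatic carbon. Within the data shown here, this is the same kind of change as the one from compound 1 to compound 2, but not the same: in compound 1 the trifluoromethyl sits para to a large group, while in compound 3 it sits ortho to a fluoro group and meta to a large group. Among these four compounds the change occurs twice in all.

For compound 4 in this assay a step of similar direction is expected, estimated as a 3.8-fold higher number from compound 3 to compound 4 (0.58 log units; beyond the scatter); this rests on the single earlier case, namely the step of a 6.1-fold higher number from compound 1 to compound 2 (0.78 log units; beyond the scatter), and on the value of compound 3 at 5300 nM, with the different surroundings of the changed group leaving the size uncertain. The value of compound 4 is therefore estimated at 20000 nM, expected to fall between 8000 nM and 55000 nM.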

Compound 4, half-maximal inhibitory concentration: 13000 nM
The estimate for compound 4 lay 1.5-fold (0.19 log units) above the measured number; low and high end bracket the measured number.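

Replacing trifluoromethyl with fluoro raised the number again in this assay, and the new step is a 2.5-fold higher number from compound 3 to compound 4 (0.39 log units; beyond the scatter). Set beside the earlier case, the two steps point the same way and their sizes cannot be told apart: the same change on two cores in this assay, a 6.1-fold higher number (0.78 log units; beyond the scatter) from compound 1 to compound 2 and a 2.5-fold higher number (0.39 log units; beyond the scatter) from compound 3 to compound 4, 2.5-fold (0.39 log units) apart, within the scatter of two such steps. This suggests that the change carries over from one core to the other in direction, and that no difference in size can be claimed, but two cases do not establish a fixed step for the series, do not show that the surroundings of the group are without influence, and do not explain why the number rises.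

The compounds shown leave open what other groups would do at this place on the aromatic ring, such as a chloro, a methoxy, a nitrile or an amine, and whether they would fall in the same order as trifluoromethyl and fluoro. They also leave open whether the step would keep its direction on cores that carry something else in place of the chloro or the hydroxyl group, such as a methyl or a carboxylic acid.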